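This account rests on a few compounds, and the source may have more. Where it says the series, first, only, none or still open, it means among the compounds named here.

Measured so far:
compound 1 `COc1ccc(-c2cc(C(C)=O)c3[nH]c(-c4ccc(OC)cc4)cc3c2)cc1` gives 60.2% in a functional assay on HeLa cells (Homo sapiens) for cytotoxicity, read by MTT assay, with a stated time of 2 days, tested at 1 uM; a higher number here means a weaker effect of the compound at the concentration tested, a lower number a stronger effect
compound 2 `CC(=O)c1cc(/C=C/c2ccc(F)cc2)cc2cc(-c3ccc(F)cc3)[nH]c12` gives 53.7% in this assay

On these two numbers compound 2 stands within the scatter of compound 1, so the two are not told apart in this assay. Compound 3 `COc1ccc(-c2cc3cc(/C=C/c4ccc(F)cc4)cc(C(C)=O)c3[nH]2)cc1` has not been measured. It differs from compound 2 in one place: methoxy in place of fluoro on an aromatic carbon. Going by the values given here, no measured pair isolates this change, so its size is unknown; compound 1 and compound 2 together suggest that neither ring end moves the number far. For compound 3 the expected step from compound 2 is a number 3.3 percentage points higher from compound 2 to compound 3 (within the scatter), not beyond the scatter. Compound 3 is therefore estimated at 57%, in the range 42% to 72%.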

Compound 3, a percentage reported as activity, at one concentration (the size of the read-out at that concentration, not a potency): 67.1%
The estimate for compound 3 lay 10.1 percentage points below the measured number; the range from low to high includes it.
By their numbers in this assay, from the lowest: compounds 2, 1 and 3 (each within the scatter of the next, the first and the last beyond it).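

Going by these compounds alone, changing 4-fluorophenyl to 4-methoxyphenyl gives a number 13.4 percentage points higher from compound 2 to compound 3 (beyond the scatter) in this assay, the first step beyond the scatter, so this place on the ring does affect the read-out, though modestly. By contrast, 2-(4-fluorophenyl)ethenyl in place of 4-methoxyphenyl gives a number 6.9 percentage points higher from compound 1 to compound 3 (within the scatter), which does not separate those two compounds. Nothing measured here explains the methoxy step. From the compounds shown here alone, whether an amine or a carboxylic acid at this place would shift the number further remains open, as does the effect of a longer chain on the oxygen.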